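This account rests on a few compounds, and the source may have more. Where it says the series, first, only, none or still open, it means among the compounds named here.

The measured compounds, each with its result in a physicochemical assay for lipophilicity, in phosphate buffer, measured as octanol-water partition, at pH 11.5; on this read-out lower numbers stand for lower lipophilicity and higher numbers for higher lipophilicity:

compound 1, `CCCCC(CC)CNC(=N)NC(=N)Nc1ccc(C)cc1`, gives 4.73
compound 2, `CCCCNC(=N)NC(=N)Nc1ccc(Cl)cc1`, gives 3.13
compound 3, `CCCCSc1ccc(NC(=N)NC(=N)NCCCCCCNC(=N)NC(=N)Nc2ccc(SCCCC)cc2)cc1`, gives 7.58

Among these three numbers compound 1 stands second highest. Its nearest neighbour is compound 2, whose value lies lower by a gap beyond the scatter, and the furthest is compound 3, whose value lies higher by a larger gap, also beyond the scatter. No two of the measured compounds differ in only one place, so none of these gaps can be tied to a single structural change.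

The unmeasured compound 4, `CCCCCCCCNC(=N)NC(=N)Nc1ccc(C)cc1`, is reached from compound 1 by one change: heptyl in place of 1-ethylpentyl on a saturated chain carbon bound to an amine nitrogen. The two compounds have the same atoms, joined differently; the chain that leaves and the chain that enters carry the same count of heavy atoms, no ring, no hydrogen-bond donors or acceptors and no charge.

Within the data shown here, with nothing among the measured compounds isolating this change, the expectation is for a step in this assay that is small, upward, and at most barely beyond the scatter, that is, a step from compound 1 to compound 4 of about a number 0.22 log units higher from compound 1 to compound 4 (within the scatter). Compound 4 is therefore estimated at 4.95, expected to fall between 4.55 and 5.4.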

Compound 4, partition coefficient: 4.93
Estimate against measurement, compound 4: 0.02 log units above; the range from low to high includes it.
By their numbers in this assay, from the lowest: compound 2; then compounds 1 and 4 (each within the scatter of the next); then compound 3.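

With compound 4, this assay gains its first step that isolates a single place: heptyl in place of 1-ethylpentyl on a saturated chain carbon bound to an amine nitrogen gives a number 0.20 log units higher from compound 1 to compound 4 (within the scatter). The earlier compounds shown here differed in more than one place, so their wide gaps could not be tied to any single change, whereas this pair shows that rejoining the same seven carbons at this position, with the rest of the core unchanged, leaves the read-out within the scatter. Nothing available bears on why the two chains give results this close, so the step stands as an observation without an explanation.

From the compounds shown here alone, it remains open whether this holds only for chains of the same heavy atom count, since a step from heptyl to a longer chain such as decyl, or to a ring-bearing group such as cyclohexylmethyl, could read quite differently in this assay. Among these compounds, also open is whether the same exchange of 1-ethylpentyl for heptyl would give a comparable step on a core carrying another group, such as methoxy, in place of the one shared by compound 1 and compound 4.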